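Dichlorophenyl anilide to methoxyphenyl in an inactive series

The compounds below may be only part of what the source reports. "The series", "measured", "known", "first", "only" and "open" are said of these compounds alone.

Compound 3 `CC(C)[C@H](NC(=O)c1cc(Cl)ccc1O)C(=O)Nc1ccc(Cl)c(Cl)c1` carries a 3,4-dichlorophenyl group on the amide-type nitrogen of the shared core. In a functional assay on K562 cells (Homo sapiens) for cytotoxicity, with a stated time of 72 h (on this read-out higher numbers stand for weaker inhibition and lower numbers for stronger inhibition), compound 3 gives only a limit, > 10000 nM. Compound 1 `CC(C)[C@H](NC(=O)c1cc(Cl)ccc1O)C(=O)Nc1ccc(Cl)cc1` likewise gives only a limit, > 20000 nM. Compound 2 `CC(C)[C@H](NC(=O)c1cc(Cl)ccc1O)C(=O)Nc1cccc(Cl)c1` also gives only a limit, > 10000 nM. The steps a step that the two limits leave unreadable from compound 1 to compound 2, a step that the two limits leave unreadable from compound 1 to compound 3 and a step that the two limits leave unreadable from compound 2 to compound 3 therefore cannot be read; two values sit at the limit of > 10000 nM in this assay, at which 2 of the 3 values shown sit, and one at the limit of > 20000 nM in this assay, at which 1 of the 3 values shown sits. Compound 4 `COc1ccc(NC(=O)[C@@H](NC(=O)c2cc(Cl)ccc2O)C(C)C)cc1` differs from compound 3 by 4-methoxyphenyl in place of 3,4-dichlorophenyl on an amide-type nitrogen. For the measured compounds named here, no measured step bears on this change, so no step beyond the scatter is expected: a step that the limit leaves unreadable from compound 3 to compound 4. Compound 4 is expected to give 15000 nM, with a range from 3000 nM to 50000 nM, and may again be reported only as a limit.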

Compound 4, half-maximal inhibitory concentration: > 10000 nM
Compound 4 gave a limit, no number; the forecaster's own chance of this, stated with the estimate: 75%; the middle value is on the limit's open side.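

Compound 4 gives only a limit, > 10000 nM, and its steps from compound 1, compound 2 and compound 3 cannot be read. From the compounds shown here alone, with only limits for all four compounds, the effect of the group on the amide-type nitrogen in this assay remains open.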